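Swapping the aryl group on the oxadiazole core

The source may hold more compounds than are shown below. What is called first, only, known or untested is meant among the compounds shown, and "the series" means these compounds.

Measured so far:
compound 1, `O=C(O)CCc1ccc(OCc2ncc(-c3cccc(F)c3)o2)cc1`, 1070 nM
compound 2, `O=C(O)CCc1ccc(OCc2ncc(-c3ccccc3)o2)cc1`, 1600 nM
compound 3, `O=C(O)CCc1ccc(OCc2nc(-c3ccccc3Cl)no2)cc1`, 1200 nM

All three compounds were tested in a functional assay on CHO cells for agonist activity at Free fatty acid receptor 1 (Homo sapiens), read by FLIPR and calcium flux, in the presence of a further agent that is not named here; on this read-out lower numbers stand for an effect already at smaller amounts and higher numbers for an effect only at larger amounts of compound. Compound 1 and compound 2 share one core and differ only in a fluoro versus a hydrogen on an aromatic carbon; that change gives a 1.5-fold higher number from compound 1 to compound 2 (0.17 log units; within the scatter), so the two cannot be told apart. Compound 3 carries a different core, and in this assay compound 3 sits within the scatter of both compound 1 and compound 2, so none of the three stands out.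

Compound 4, `Cc1ccc(-c2noc(COc3ccc(CCC(=O)O)cc3)n2)cc1`, keeps the core of compound 3 and differs by 4-methylphenyl in place of 2-chlorophenyl on an aromatic carbon. Within the data shown here, no measured step uses this core, and the only step that changes a substituent on the pendant phenyl ring is the one from compound 1 to compound 2, which stayed within the scatter. With so little to go on, the expectation for compound 4 is a step of no change at the digits printed from compound 3 to compound 4 (within the scatter), that is, no change beyond the scatter. Compound 4 is therefore estimated at 1200 nM, with a range from 400 nM to 3600 nM.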

Compound 4, half-maximal effective concentration: 300 nM
The estimate for compound 4 lay 4.0-fold (0.60 log units) above the measured number; measured number below the stated range.
By their numbers in this assay, from the lowest: compound 4; then compounds 1, 3 and 2 (each within the scatter of the next).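

In this assay, putting 4-methylphenyl in place of 2-chlorophenyl on this aromatic carbon, between two ring nitrogen atoms, gives a 4.0-fold lower number from compound 3 to compound 4 (0.60 log units; beyond the scatter). Among these compounds, this is the first step to go beyond the scatter, so the number at this position does respond to a change of aryl group, even though both groups have the same count of heavy atoms and one aromatic ring each. Nothing available explains why the number moves.

The step changes the substituent and its place on the phenyl ring together, so the compounds shown cannot separate chloro versus methyl from the shift in position; 4-chlorophenyl and 2-methylphenyl would pull these apart. From the compounds shown here alone, whether 4-methylphenyl gives a similar step on the core of compound 1 also stays open.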